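Chloro for hydrogen on a fused purine-like core

The source may report more compounds than this note shows. Statements on the series, on what has been measured and on what is new or still open speak of the compounds shown alone.

Compound 1 `ClCc1cccc(Cn2cnc3ncnc(Cl)c32)c1`: 47900 nM
Compound 2 `ClCc1cccc(Cn2cnc3c(Cl)ncnc32)c1`: 70800 nM
Compound 3 `ClCc1ccc(Cn2cnc3nc(Cl)nc(Cl)c32)cc1`: "not determined" (no result reported)

Three compounds share a fused two-ring core carrying a chloromethylbenzyl group. In a functional assay on RXF 393 cells (Homo sapiens) for cytotoxicity, read by sulforhodamine B assay, with a stated time of 48 h (on this read-out lower numbers stand for higher toxicity in this test and higher numbers for lower toxicity in this test), compound 1 gives 47900 nM, and compound 2 gives 70800 nM. Compound 2 holds the highest of the two numbers, yet the gap to compound 1 lies within the scatter, so the two cannot be told apart on this read-out. For compound 3 the entry in this assay reads "not determined" (no result reported), so no value was obtained.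

Compound 4 `ClCc1cccc(Cn2cnc3c(Cl)nc(Cl)nc32)c1` differs from compound 2 by chloro in place of hydrogen on an aromatic carbon. Among the measured compounds shown here, no measured pair shows the effect of such a change on this core, so nothing in the data points in either direction. The expectation for this assay is therefore a step of no size beyond the scatter, and the estimated step of a 1.2-fold lower number from compound 2 to compound 4 (0.07 log units; within the scatter) is set accordingly. Compound 4 is expected to give 60000 nM, with a range from 20000 nM to 180000 nM.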

Compound 4, concentration lethal to 50% of the cells: 5120 nM
The estimate for compound 4 lay 12-fold (1.07 log units) above the measured number; measured number below the stated range.
By their numbers in this assay, from the lowest: compound 4; then compounds 1 and 2 (each within the scatter of the next).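

Chloro in place of hydrogen on an aromatic carbon, between two ring nitrogen atoms, gives in this assay a 14-fold lower number from compound 2 to compound 4 (1.14 log units; beyond the scatter) and is the first single change here with a readable effect on the number. This position of the shared core is therefore not indifferent to substitution, and on this read-out the change goes toward higher toxicity in this test. No measurement at hand speaks to what lies behind a step of this size.

On these data alone, whether an amine, a methoxy group or bromo at this same position would give a similar step remains open. Also open, as far as these compounds go, is whether chloro at the matching place on the core of compound 1 would lower the number as well, and compound 3 offers no number to help.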